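Dimethylamino for pyrrolidin-1-yl on a carbonyl carbon

The source may report more compounds than this note shows. Statements on the series, on what has been measured and on what is new or still open speak of the compounds shown alone.

In a functional assay on MCF7 cells (Homo sapiens) for cytotoxicity, read by MTT assay, with a stated time of 72 h (on this read-out higher numbers stand for weaker inhibition and lower numbers for stronger inhibition), compound 1 `COc1ncc(-c2ccc3nc(NC(=O)NCC(=O)N4CCCCC4)nn3c2)cc1NS(=O)(=O)c1ccc(F)cc1` gives 570 nM while compound 2 `COc1ncc(-c2ccc3nc(NC(=O)N4CCCC4)nn3c2)cc1NS(=O)(=O)c1ccc(F)cc1` gives 1660 nM and so holds the higher of the two numbers, which means the weaker inhibition. Compound 3 `COc1ncc(-c2ccc3nc(NC(=O)N(C)C)nn3c2)cc1NS(=O)(=O)c1ccc(F)cc1` has not yet been measured. It differs from compound 2 by dimethylamino in place of pyrrolidin-1-yl on a carbonyl carbon and so gives up the five-membered ring. For the measured compounds named here, the only measured step at this carbonyl carbon is modest, a 2.9-fold higher number from compound 1 to compound 2 (0.46 log units; beyond the scatter) and beyond the scatter, but it involves a different and much longer group. It gives no direction for dimethylamino, so no shift beyond the scatter is expected in this assay for this change. The expected step is a 1.0-fold higher number from compound 2 to compound 3 (0.01 log units; within the scatter) on this reasoning. Compound 3 is estimated at 1700 nM (expected range 750 nM to 3800 nM).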

Compound 3, half-maximal inhibitory concentration: 1560 nM
For compound 3 the middle estimate is 1.1-fold (0.04 log units) above the measured one; measured number inside the range.
By their numbers in this assay, from the lowest: compound 1; then compounds 3 and 2 (each within the scatter of the next).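

In this assay, exchanging the five-membered ring of pyrrolidin-1-yl for open-chain dimethylamino on the carbonyl carbon gives a 1.1-fold lower number from compound 2 to compound 3 (0.03 log units; within the scatter) and so shows that, for this pair, the ring makes no difference beyond the scatter. The longer (((piperidin-1-yl)carbonyl)methyl)amino group of compound 1 now stands apart from a second short group, with a 2.7-fold higher number from compound 1 to compound 3 (0.44 log units; beyond the scatter) as the step, so the earlier gap is not tied to pyrrolidin-1-yl alone. No measurement at hand accounts for either step.

Which part of the longer group goes with the lower number in compound 1 remains open. A plain methylamino group, or the same chain ending in a carboxylic acid instead of the piperidine amide, would bear on that question.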